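Removing a Methoxy Group: Compound 3 to Compound 4

This account rests on a few compounds, and the source may have more. Where it says the series, first, only, none or still open, it means among the compounds named here.

Measured so far, in a functional assay on HCT-116 cells (Homo sapiens) for inhibition, read by sulforhodamine B assay, with a stated time of 48 h, tested at 50 uM; a lower number here means less inhibition of growth, a higher number more inhibition of growth at the concentration tested:
compound 1, `COc1ccc(/C=C/C(=O)/C=C/c2ccc(OCc3cn(CCCCCOc4cc(=O)oc5ccccc45)nn3)c(OC)c2)cc1`: 35%
compound 2, `COc1cc(/C=C/C(=O)/C=C/c2cc(OC)c(OC)c(OC)c2)ccc1OCc1cn(CCCCCOc2cc(=O)oc3ccccc23)nn1`: 53%
compound 3, `COc1ccccc1/C=C/C(=O)/C=C/c1ccc(OCc2cn(CCCCCOc3cc(=O)oc4ccccc34)nn2)c(OC)c1`: 33%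

Among these three, compound 3 has the lowest number. Its nearest neighbour is compound 1, and the gap between them lies within the scatter, so the two cannot be told apart. The only clear separation is to compound 2: a number 20 percentage points lower from compound 2 to compound 3 (beyond the scatter).

Compound 4, `COc1cc(/C=C/C(=O)/C=C/c2ccccc2)ccc1OCc1cn(CCCCCOc2cc(=O)oc3ccccc23)nn1`, differs from compound 3 in one spot: hydrogen in place of methoxy on an aromatic carbon. Among the compounds with values here, no measured pair removes a methoxy group outright, so the closest guides are the steps that move or add such groups. Moving a single methoxy from one aromatic carbon to another gave a number 2 percentage points lower from compound 1 to compound 3 (within the scatter), a step within the scatter. Adding two further methoxy groups gave a number 18 percentage points higher from compound 1 to compound 2 (beyond the scatter), a modest rise. Taken together, one methoxy group seems to matter little, while several together matter somewhat. Losing the single methoxy of compound 3 is therefore expected to bring at most a small fall, and quite possibly nothing beyond the scatter, so the estimated step is a number 5 percentage points lower from compound 3 to compound 4 (within the scatter). For compound 4 the expected value is 28%, with a range from 14% to 42%.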

Compound 4, percent growth inhibition at one concentration: 24%
For compound 4 the middle estimate is 4 percentage points above the measured one; the measured number falls inside the stated range.
By their numbers in this assay, from the lowest: compounds 4, 3 and 1 (each within the scatter of the next, the first and the last beyond it); then compound 2.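

In this assay, taking the methoxy off 2-methoxyphenyl to leave phenyl gives a number 9 percentage points lower from compound 3 to compound 4 (within the scatter), so this single group at this place cannot be shown to matter. Taking the methoxy off 4-methoxyphenyl gives a number 11 percentage points lower from compound 1 to compound 4 (beyond the scatter), a modest fall, yet compound 1 and compound 3 lie within the scatter of each other, so the methoxy of one cannot be ranked above that of the other. The clearest effect comes from removing all the methoxy groups of 3,4,5-trimethoxyphenyl, which gives a number 29 percentage points lower from compound 2 to compound 4 (beyond the scatter), so more methoxy groups go with more growth inhibition across compound 2, compound 1 and compound 4, while compound 3 goes against any rule that each single methoxy counts.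

Nothing available accounts for the sizes of these steps.

From the compounds shown here alone, it remains open whether a different group on this ring, such as a hydroxyl, an amine or a fluorine atom, would move the number as the methoxy groups do, and whether two methoxy groups on the ring would already give part of the rise seen with three.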